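Methylamino at the ring position where methyl gave nothing

The source may hold more compounds than are shown below. What is called first, only, known or untested is meant among the compounds shown, and "the series" means these compounds.

Compound 2 `O=C(Nc1ccc(-n2ncc3ccccc32)cc1)Nc1ccc(Cl)c(C(F)(F)F)c1` gives 32000 nM in a functional assay on OS-RC-2 cells (Homo sapiens) for cytotoxicity, read by MTT assay, with a stated time of 72 h (a lower number here means a stronger inhibitor, a higher number a weaker inhibitor), level with compound 1 `Cc1cccc2c1cnn2-c1ccc(NC(=O)Nc2ccc(Cl)c(C(F)(F)F)c2)cc1`, which gives 32000 nM. Going by the values given here, the one step in hand, hydrogen in place of methyl on an aromatic carbon, ran no change at the digits printed from compound 1 to compound 2 (within the scatter). Compound 3 `CNc1cccc2c1cnn2-c1ccc(NC(=O)Nc2ccc(Cl)c(C(F)(F)F)c2)cc1` carries methylamino in place of hydrogen on an aromatic carbon, on an aromatic carbon of a six-membered aromatic ring of carbon only, part of a fused or bridged system of two rings, ortho to a fused ring and meta to a fused ring. Because no change at the digits printed from compound 1 to compound 2 (within the scatter) showed no movement at this position, the step of no change at the digits printed from compound 2 to compound 3 (within the scatter) is expected to stay within the scatter. Compound 3 is estimated at 32000 nM, range 12000 nM to 80000 nM.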

Compound 3, half-maximal inhibitory concentration: 10600 nM
Compound 3: middle estimate off by 3.0-fold (0.48 log units), on the high side; measured number below the stated range.
By their numbers in this assay, from the lowest: compound 3; then compounds 1 and 2 (each within the scatter of the next).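

The position is not silent in this assay: methylamino in place of hydrogen gives a 3.0-fold lower number from compound 2 to compound 3 (0.48 log units; beyond the scatter), and methylamino in place of methyl gives a 3.0-fold lower number from compound 1 to compound 3 (0.48 log units; beyond the scatter). Methyl and hydrogen stayed level at this carbon, so the response here depends on which group enters. No measurement at hand explains the step.

Still open, from the compounds shown here alone, is whether an unsubstituted amine, dimethylamino or methoxy on this carbon would match methylamino. Also open, going by these compounds, is whether a longer chain on the nitrogen would lower the number further.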